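Swapping the acid-bearing chain on a thromboxane receptor blocker

The source may report more compounds than this note shows. Statements on the series, on what has been measured and on what is new or still open speak of the compounds shown alone.

Measured compounds:
compound 1 `O=C(O)COCCCCC1=CCC[C@@H]1NS(=O)(=O)c1ccc(F)cc1F`, 1800 nM
compound 2 `O=C(O)COCCCCC1=CCC[C@@H]1NS(=O)(=O)c1ccccc1`, 2000 nM

In a functional assay on a cell-free system (plasma) for inhibition of thromboxane A2 receptor (Homo sapiens), read by turbidimetry (on this read-out higher numbers stand for weaker inhibition and lower numbers for stronger inhibition), compound 1 gives the lowest of the two numbers; compound 2 sits nearest, and a 1.1-fold higher number from compound 1 to compound 2 (0.05 log units; within the scatter). That step changes only the group on the sulfonyl sulfur. Compound 3 `O=C(O)CC/C=C\CC1=CCC[C@@H]1NS(=O)(=O)c1ccc(F)cc1F` differs from compound 1 elsewhere: 4-carboxybut-1-en-1-yl in place of 3-(carboxymethoxy)propyl on a saturated chain carbon bound to a double-bonded ring carbon. Going by the values given here, no measured step touches this chain, so the single measured step gives no direction for it. The number for compound 3 is therefore expected to stay near that of compound 1, with a 1.2-fold lower number from compound 1 to compound 3 (0.08 log units; within the scatter) as the estimated step. The estimate for compound 3 is 1500 nM, in a range from 400 nM to 6000 nM.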

Compound 3, half-maximal inhibitory concentration: 20000 nM
For compound 3 the middle estimate is 13-fold (1.12 log units) below the measured one; the measured number lies above the stated range.
By their numbers in this assay, from the lowest: compounds 1 and 2 (each within the scatter of the next); then compound 3.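

In this assay, this chain position proves sensitive: 4-carboxybut-1-en-1-yl in place of 3-(carboxymethoxy)propyl gives an 11-fold higher number from compound 1 to compound 3 (1.05 log units; beyond the scatter), which means much weaker inhibition. The earlier change on the sulfonyl sulfur stayed within the scatter, so this is the first clear change in potency among these compounds. No measurement available here accounts for the loss. From the compounds shown here alone, the two chains differ in both their oxygen count and their double bonds, and which difference matters stays open. So does the effect of a longer chain or of a tetrazole in place of the carboxylic acid.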